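Replacing 2-(hydroxymethyl)phenyl with 4-bromophenyl in compound 3

A few compounds are considered here, and "the series" means these few. Any claim that something is new, unique, unknown or untested is made for them only; others in the source may bear on it.

Measured in a functional assay on MIA PaCa-2 cells (Homo sapiens) for inhibition, read by MTT assay, with a stated time of 72 h, tested at 30 uM; a lower number here means less inhibition of growth, a higher number more inhibition of growth at the concentration tested:
compound 1 `C=CCc1ccc(OCc2cn(-c3cc(OC)c(OC)c(OC)c3)nn2)c(O)c1`: 41.1%
compound 2 `C=CCc1ccc(OCc2cn(-c3ccc(OC)cc3)nn2)c(O)c1`: 62.3%
compound 3 `C=CCc1ccc(OCc2cn(-c3ccccc3CO)nn2)c(O)c1`: 39.6%

Compound 3 gives 39.6%, within the scatter of compound 1 at 41.1%, so these two cannot be ranked against each other. Both numbers lie well under that of compound 2 at 62.3%.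

The next compound is compound 4 `C=CCc1ccc(OCc2cn(-c3ccc(Br)cc3)nn2)c(O)c1`, which keeps the shared core and differs from compound 3 at one place: 4-bromophenyl in place of 2-(hydroxymethyl)phenyl on an aromatic nitrogen. It has 4-bromophenyl in place of 2-(hydroxymethyl)phenyl on an aromatic nitrogen.

Among the compounds with values here, only one measured step bears on this place. This is a number 22.7 percentage points lower from compound 2 to compound 3 (beyond the scatter), a modest change beyond the scatter, in which 2-(hydroxymethyl)phenyl replaced 4-methoxyphenyl. The new compound gives up that same 2-(hydroxymethyl)phenyl, and its group again carries a single substituent named at the 4 position, as in compound 2. Bromine is not methoxy, however, and the data hold no bromine compound, so only part of that step is expected to return. The expected change is upward, an estimated a number 14.4 percentage points higher from compound 3 to compound 4 (beyond the scatter). For compound 4 the estimated value is 54%, with an expected range from 38% to 70%.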

Compound 4, percent growth inhibition at one concentration: 43.3%
Compound 4: middle estimate off by 10.7 percentage points, on the high side; low and high end bracket the measured number.
By their numbers in this assay, from the lowest: compounds 3, 1 and 4 (each within the scatter of the next); then compound 2.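

In this assay, the exchange of 2-(hydroxymethyl)phenyl for 4-bromophenyl gives a number 3.7 percentage points higher from compound 3 to compound 4 (within the scatter) and so leaves the number unresolved, even though the entering group has 0 hydrogen-bond donors and 0 hydrogen-bond acceptors where the leaving group has 1 of each. With the substituent held at the 4 position, bromo in place of methoxy gives a number 19 percentage points lower from compound 2 to compound 4 (beyond the scatter) and shows that a single substituent at that position is not enough to reach the number of compound 2, so the earlier drop a number 22.7 percentage points lower from compound 2 to compound 3 (beyond the scatter) cannot be read as a matter of the 2-(hydroxymethyl)phenyl group alone. Nothing available gives a reason for these differences.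

The compounds shown leave open whether 4-methoxyphenyl is unusual among groups at this place or whether close relatives such as 4-ethoxyphenyl or 4-aminophenyl would give a number like that of compound 2. They also leave open how unsubstituted phenyl would compare, which would show whether methoxy raises the number or bromo and hydroxymethyl lower it.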